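The source may report more compounds than this note shows. Statements on the series, on what has been measured and on what is new or still open speak of the compounds shown alone.

Working notes on the series built on the shared core of compound 1 (`CCCCc1ccc2[nH]c(-c3ccc(OC)cc3)c(/C=N/NC(=O)c3ccc(Cl)cc3)c2c1`). In a functional assay on MCF7 cells (Homo sapiens) for antiproliferative activity, with a stated time of 5 days (a higher number here means a weaker inhibitor, a lower number a stronger inhibitor), compound 1 gives 220 nM as the only numerical result so far. Compound 2 (`CCCCc1ccc2[nH]c(-c3ccc(OC)cc3)c(/C=N/NC(=O)c3cccc(OC)c3)c2c1`) has "not determined" (no result reported) as its entry. Compound 3 (`CCCCc1ccc2[nH]c(-c3ccc(OC)cc3)c(/C=N/NC(=O)c3cccc(O)c3)c2c1`) has "not determined" (no result reported) as its entry, so it offers no number to start from. Compound 4 (`CCCCc1ccc2[nH]c(-c3ccc(OC)cc3)c(/C=N/NC(=O)c3cccnc3)c2c1`) carries pyridin-3-yl in place of 3-hydroxyphenyl on a carbonyl carbon and is still unmeasured. Within the data shown here, no measured step exists, so the only anchor is compound 1 at 220 nM and a moderate loss of potency beyond the scatter is expected in this assay for compound 4. For compound 4 the estimated value is 500 nM with an expected range from 150 nM to 2500 nM in this measurement.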

Compound 4, half-maximal inhibitory concentration: 75 nM
Estimate against measurement, compound 4: 6.7-fold (0.82 log units) above, outside the stated range (below it).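

In this assay the position on the carbonyl carbon gives its first readable step, a 2.9-fold lower number from compound 1 to compound 4 (0.47 log units; beyond the scatter), so this position accepts pyridin-3-yl in place of 4-chlorophenyl with a stronger inhibitor as the result. Steps involving compound 2 or compound 3 cannot be read. Nothing available here bears on the reason for this gain.

Going by these compounds, it remains open whether a saturated ring such as piperidin-3-yl, or a phenyl ring carrying a carboxylic acid or an amine, would keep this potency on the same carbonyl carbon.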